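A few compounds are considered here, and "the series" means these few. Any claim that something is new, unique, unknown or untested is made for them only; others in the source may bear on it.

Measured so far:
compound 1 `COc1cc[nH]c1/C=C1\C(=O)Nc2ccc(F)c(I)c21` — > 30000 nM
compound 2 `COc1cc[nH]c1/C=C1\C(=O)Nc2ccc(F)c(C#C[C@@H](C)O)c21` — 110 nM
compound 3 `CN[C@@H](C#Cc1c(F)ccc2c1/C(=C/c1[nH]ccc1OC)C(=O)N2)CO` — 300 nM

In a functional assay on MDA-MB-435 cells (Homo sapiens) for inhibition (a higher number here means a weaker inhibitor, a lower number a stronger inhibitor), compound 1 gives only a limit, > 30000 nM. Compound 2 gives 110 nM and compound 3 gives 300 nM, the higher of the two numbers measured, with a 2.7-fold higher number from compound 2 to compound 3 (0.44 log units; beyond the scatter). Compound 4 `CCN[C@H](C#Cc1c(F)ccc2c1/C(=C/c1[nH]ccc1OC)C(=O)N2)CO` differs from compound 3 by 1-(ethylamino)-2-hydroxyethyl in place of 2-hydroxy-1-(methylamino)ethyl on a triple-bonded carbon. Within the data shown here, no measured step alters the amine alkyl alone: the nearest comparison, a 2.7-fold higher number from compound 2 to compound 3 (0.44 log units; beyond the scatter), exchanges the whole chain end and was modest, while the large steps of an at least 270-fold lower number from compound 1 to compound 2 (2.43 log units; beyond the scatter) and an at least 100-fold lower number from compound 1 to compound 3 (2.00 log units; beyond the scatter) concern the alkynyl chain in place of iodo. The single added carbon is expected to shift this assay little, no change at the digits printed from compound 3 to compound 4 (within the scatter) likely within the scatter. Compound 4 is estimated at 300 nM (range 120 nM to 750 nM).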

Compound 4, half-maximal inhibitory concentration: 1160 nM
Compound 4: the middle estimate sits 3.9-fold (0.59 log units) below what was measured, and the stated range ends below it.
By their numbers in this assay, from the lowest: compound 2; then compound 3; then compound 4. At a limit, above all of these: compound 1.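

In this assay the chain end is sensitive to a small exchange: 1-(ethylamino)-2-hydroxyethyl in place of 2-hydroxy-1-(methylamino)ethyl gives a 3.9-fold higher number from compound 3 to compound 4 (0.59 log units; beyond the scatter) and so reaches further than the modest earlier change at this carbon. Measured against 1-hydroxyethyl, the same chain end gives an 11-fold higher number from compound 2 to compound 4 (1.02 log units; beyond the scatter) as a large loss. The alkynyl chain still holds a large gain over iodo, with an at least 25-fold lower number from compound 1 to compound 4 (1.41 log units; beyond the scatter) read against a limit for compound 1: the limit of > 30000 nM in this assay, at which 1 of the 4 values shown sits.

As drawn, compound 3 and compound 4 carry opposite configurations at their defined stereocentre, so the ethyl group and the configuration cannot be separated in this step. Open too, going by these compounds, is how a primary amine or a propyl group on the nitrogen would read, in either configuration.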